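The source may report more compounds than this note shows. Statements on the series, on what has been measured and on what is new or still open speak of the compounds shown alone.

Series notes. The shared core of compound 1 `O=C(CCNC(=O)c1cc(-c2ccc(F)cc2)[nH]n1)NO` carries a hydroxamic acid on a chain off the amide nitrogen; compound 2 `O=C(CCCNC(=O)c1cc(-c2ccc(F)cc2)[nH]n1)NO` and compound 3 `O=C(CCCCCCNC(=O)c1cc(-c2ccc(F)cc2)[nH]n1)NO` lengthen that chain. In an assay on cells for inhibition of protein deacetylase HDAC6 (Homo sapiens), read by fluorescence, with stated times of 15 min and 60 min (a lower number here means a stronger inhibitor, a higher number a weaker inhibitor), compound 1 gives only a limit, > 5000 nM. Compound 2 gives 1060 nM and compound 3 gives 22 nM, the lowest of the two numbers shown; the steps read an at least 4.7-fold lower number from compound 1 to compound 2 (0.67 log units; beyond the scatter) and a 48-fold lower number from compound 2 to compound 3 (1.68 log units; beyond the scatter), with an at least 220-fold lower number from compound 1 to compound 3 (2.35 log units; beyond the scatter) across the whole span.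

Compound 4 `O=C(CCCCNC(=O)c1cc(-c2ccc(F)cc2)[nH]n1)NO` shortens the chain again: hydroxycarbamoyl in place of 2-(hydroxycarbamoyl)ethyl on a saturated chain carbon, four bonds along the chain from an amide-type nitrogen. Since lengthening by one or three carbons gave the two large steps above, a shortening by two carbons is expected to raise the number, landing between compound 2 and compound 3. For compound 4 a step of a 14-fold higher number from compound 3 to compound 4 (1.13 log units; beyond the scatter) is expected, giving an estimated 300 nM (range 100 nM to 900 nM).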

Compound 4, half-maximal inhibitory concentration: 275 nM
Compound 4: the middle estimate sits 1.1-fold (0.04 log units) above what was measured, and the stated range covers the measured number.
By their numbers in this assay, from the lowest: compound 3; then compound 4; then compound 2. At a limit, above all of these: compound 1.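

In this assay, the chain now gives an ordered series: a 3.9-fold lower number from compound 2 to compound 4 (0.59 log units; beyond the scatter) and a 13-fold higher number from compound 3 to compound 4 (1.10 log units; beyond the scatter), so the number falls from compound 2 through compound 4 to compound 3. The step linking compound 2 and compound 4 is modest, while the step linking compound 3 and compound 4 is large. Compound 1 gives only a limit, so an at least 18-fold lower number from compound 1 to compound 4 (1.25 log units; beyond the scatter) is a bound and not a measured gap: the limit of > 5000 nM in this assay, at which 1 of the 4 values shown sits.

The compounds shown leave open whether a longer chain than that of compound 3 lowers the number further. They also leave open how a carboxylic acid in place of hydroxycarbamoyl would read.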